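Substituting the triazole nitrogen with a hydroxypropyl chain

The source may report more compounds than this note shows. Statements on the series, on what has been measured and on what is new or still open speak of the compounds shown alone.

Compound 2 `Cn1nc(Cc2nnc(SCCCCCCCC(=O)Nc3ccc(Cl)cc3Cl)[nH]2)c2ccccc2c1=O` gives 3500 nM in an assay on 32D cells for inhibition of interleukin-15 (Mus musculus), read by resazurin assay, with stated times of 30 min and 2.5 days, in the presence of a further agent that is not named here (on this read-out higher numbers stand for weaker inhibition and lower numbers for stronger inhibition), the lowest of the two numbers shown, with compound 1 `Cn1c(Cc2nn(C)c(=O)c3ccccc23)nnc1SCCCCCCCC(=O)Nc1ccc(Cl)cc1Cl` at 3900 nM, a difference within the scatter. Compound 3 `Cn1nc(Cc2nnc(SCC(=O)Nc3ccc(Cl)cc3Cl)n2CCCO)c2ccccc2c1=O` reports only a limit, > 30000 nM, at the limit of > 30000 nM in this assay, at which 1 of the 3 values shown sits. Compound 4 `Cn1nc(Cc2nnc(SCCCCCCCC(=O)Nc3ccc(Cl)cc3Cl)n2CCCO)c2ccccc2c1=O` differs from compound 2 by 3-hydroxypropyl in place of hydrogen on an aromatic nitrogen. Among the measured compounds shown here, one measured step touches this nitrogen: a 1.1-fold lower number from compound 1 to compound 2 (0.05 log units; within the scatter), so exchanging one small group for another there changed little. A longer chain carrying a hydroxyl is a larger change, and compound 3, which also bears a 3-hydroxypropyl on that nitrogen, gave only a limit, though its linker is shorter. Compound 4 is therefore expected near compound 2, perhaps somewhat weaker, about 6000 nM (range 1500 nM to 25000 nM), a step of a 1.7-fold higher number from compound 2 to compound 4 (0.23 log units; within the scatter).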

Compound 4, half-maximal inhibitory concentration: > 30000 nM
Compound 4: only a limit was reported (the forecaster's own chance of this, stated with the estimate: 25%); middle value at least 5.0-fold (0.69 log units) from the limit.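

Replacing hydrogen with 3-hydroxypropyl on this aromatic nitrogen gives an at least 8.5-fold higher number from compound 2 to compound 4 (0.93 log units; beyond the scatter), and against the methyl group the step is an at least 7.6-fold higher number from compound 1 to compound 4 (0.88 log units; beyond the scatter), so this position does not accept every group. The long linker of compound 4 does not rescue activity, which means the short linker of compound 3 need not explain that compound's result. The reading for compound 4 is a limit, not a number, so the full size of the loss is unknown: the limit of > 30000 nM in this assay, at which 2 of the 4 values shown sit.

From the compounds shown here alone, whether the chain's length or its hydroxyl matters stays open. A plain propyl or a chain ending in an amine on this nitrogen would help separate the two.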